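Aminopyridine in place of methylpyrazole: expected solubility

The compounds below may be only part of what the source reports. "The series", "measured", "known", "first", "only" and "open" are said of these compounds alone.

Measured compounds in a physicochemical assay for solubility, at pH 7.4; on this read-out higher numbers stand for higher solubility and lower numbers for lower solubility:
- compound 1, `Cc1cc(Cl)c(-c2cn(C)c(C)n2)cc1NC(=O)c1ccc(OCc2ccccn2)cc1`, gives < 1000 nM, which is a limit of the assay and not a number.
- compound 2, `Cc1ccc(-c2c[nH]cn2)cc1NC(=O)c1ccc(OCc2ccccn2)cc1`, gives 90000 nM.
- compound 3, `Cc1cc(C)c(-c2c[nH]nc2C)cc1NC(=O)c1ccc(OCc2ccccn2)cc1`, gives 33000 nM.

Among the two compounds with a number in this assay, compound 3 stands lowest; compound 2 gives the higher number, and the gap between the two lies beyond the usual scatter. Compound 1 sits at the limit (the limit of < 1000 nM in this assay, at which 1 of the 3 values shown sits), so it cannot be ranked against compound 3. Among the measured compounds shown here, no pair of these three compounds differs in only one place, so no single step has been measured.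

Compound 4, `Cc1cc(C)c(-c2cccc(N)n2)cc1NC(=O)c1ccc(OCc2ccccn2)cc1`, differs from compound 3 by 6-aminopyridin-2-yl in place of 3-methyl-1H-pyrazol-4-yl on an aromatic carbon. Nothing measured here isolates this change, so the expectation rests on the spread of the numbers in hand. For compound 4 the expected step is a 1.2-fold higher number from compound 3 to compound 4 (0.08 log units; within the scatter), within the scatter. Compound 4 is estimated at 40000 nM, between 10000 nM and 150000 nM.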

Compound 4, solubility: 2000 nM
Beside the measured number, compound 4's estimate is 20-fold (1.30 log units) above it; measured number below the stated range.
By their numbers in this assay, from the lowest: compound 4; then compound 3; then compound 2. At a limit, below all of these: compound 1.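

The group on this aromatic carbon, ortho to a methyl group and para to another methyl group, has a strong bearing on the read-out in this assay: 6-aminopyridin-2-yl in place of 3-methyl-1H-pyrazol-4-yl gives a 17-fold lower number from compound 3 to compound 4 (1.22 log units; beyond the scatter). This is the only single change measured among these compounds, so a large step can now be tied to this one position, which the spread among the earlier compounds could not do. Compound 1 carries a limit and not a number, and little readable range remains under compound 4: the limit of < 1000 nM in this assay, at which 1 of the 4 values shown sits.

The step changes the ring size and the hetero atoms together, so the compounds shown do not tell which of these carries it. On these data alone, whether a plain pyridin-2-yl without the amine would sit nearer compound 3 or compound 4 also stays open.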